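The compounds below may be only part of what the source reports. "The series", "measured", "known", "first", "only" and "open" are said of these compounds alone.

Measured in a functional assay on A549 cells (Homo sapiens) for cytotoxicity, read by MTT assay, with a stated time of 48 h; a lower number here means a stronger inhibitor, a higher number a weaker inhibitor:
- compound 1 `COc1cc([C@H]2C[C@]2(CO)C(=O)NCc2ccc(C)cc2)cc(OC)c1OC`: 60700 nM
- compound 2 `COc1cc([C@H]2C[C@]2(CO)C(=O)Nc2ccccc2)cc(OC)c1OC`: > 100000 nM, which is a limit and not a number

Going by the values given here, compound 1 therefore holds the only true number so far. Compound 3 `COc1cc([C@H]2C[C@@]2(CO)C(=O)NCc2ccc(C)cc2)cc(OC)c1OC` keeps all its atoms and bonds, and the change is purely one of configuration: the two compounds have the same atoms and bonds and differ only in configuration as drawn: 1 of 2 stereo elements differ; a stereocentre at a saturated ring carbon is drawn S in compound 1 and R in compound 3. Among the compounds with values here, the single measured step, an at least 1.6-fold higher number from compound 1 to compound 2 (0.21 log units; that floor lies within the scatter), concerns a different place in the molecule, so it offers little guidance here. With no measured change of configuration to go on, no step beyond the scatter is expected in this assay, and the expected step is a 1.2-fold higher number from compound 1 to compound 3 (0.06 log units; within the scatter). For compound 3 the estimated value is 70000 nM, with an expected range of 30000 nM to 150000 nM.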

Compound 3, half-maximal inhibitory concentration: 63800 nM
Beside the measured number, compound 3's estimate is 1.1-fold (0.04 log units) above it, and the stated range covers the measured number.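

Redrawing the saturated ring carbon from S to R gives a 1.1-fold higher number from compound 1 to compound 3 (0.02 log units; within the scatter) in this assay. Going by these compounds alone, this is the first measured change at this stereocentre, and in this pair the drawn configuration makes no difference beyond the scatter, which the step on the amide nitrogen could not show. The comparison rests on a single change: the fact that compounds 1 and 3 differ only in the configuration as drawn

Still open, as far as these compounds go, is whether the other stereocentre behaves the same way. Also open, from the compounds shown here alone, is whether an amine or a carboxylic acid in place of the hydroxymethyl group would move the number.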